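Swapping the Boc group for a tert-butyl urea on the pyrrolidine

This account rests on a few compounds, and the source may have more. Where it says the series, first, only, none or still open, it means among the compounds named here.

Measured compounds in an assay on isolated protein for binding affinity to secreted frizzled-related protein 1 (Homo sapiens), read by fluorescence; on this read-out lower numbers stand for stronger inhibition and higher numbers for weaker inhibition:
compound 1, `O=C(Cn1ccnc1)N1CCC(NS(=O)(=O)c2cc(S(=O)(=O)c3ccccc3)ccc2C(F)(F)F)CC1`, 30 nM
compound 2, `CC(C)(C)OC(=O)N1CCC[C@@H]1C(=O)N1CCC(NS(=O)(=O)c2cc(S(=O)(=O)c3ccccc3)ccc2C(F)(F)F)CC1`, 120 nM
compound 3, `CN(C)CC(=O)N1CCC[C@H]1C(=O)N1CCC(NS(=O)(=O)c2cc(S(=O)(=O)c3ccccc3)ccc2C(F)(F)F)CC1`, 90 nM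

Compound 2 gives the highest number of the three. Its nearest neighbour is compound 3, with a 1.3-fold lower number from compound 2 to compound 3 (0.12 log units; within the scatter), a gap that stays within the scatter. The furthest is compound 1, with a 4.0-fold higher number from compound 1 to compound 2 (0.60 log units; beyond the scatter), a modest step beyond the scatter; compound 3 sits apart from compound 1 by a similar margin, a 3.0-fold higher number from compound 1 to compound 3 (0.48 log units; beyond the scatter).

Compound 4, `CC(C)(C)NC(=O)N1CCC[C@H]1C(=O)N1CCC(NS(=O)(=O)c2cc(S(=O)(=O)c3ccccc3)ccc2C(F)(F)F)CC1`, has not been measured yet. Its change from compound 2 is 1-((tert-butyl)carbamoyl)pyrrolidin-2-yl in place of 1-(tert-butoxycarbonyl)pyrrolidin-2-yl on a carbonyl carbon. For the measured compounds named here, the step that bears on it most directly is the one from compound 2 to compound 3, where a different group on the pyrrolidine nitrogen replaced the tert-butoxycarbonyl and the number stayed within the scatter. On that basis no step beyond the scatter is expected in this assay, so compound 4 is expected at 110 nM, with a range from 50 nM to 250 nM, which amounts to an expected 1.1-fold lower number from compound 2 to compound 4 (0.04 log units; within the scatter).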

Compound 4, half-maximal inhibitory concentration: 20 nM
For compound 4 the middle estimate is 5.5-fold (0.74 log units) above the measured one; the measured number lies below the stated range.
By their numbers in this assay, from the lowest: compounds 4 and 1 (each within the scatter of the next); then compounds 3 and 2 (each within the scatter of the next).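

In this assay, the group on the pyrrolidine nitrogen turns out to matter: the 1-((tert-butyl)carbamoyl)pyrrolidin-2-yl group gives a 6.0-fold lower number from compound 2 to compound 4 (0.78 log units; beyond the scatter) and a 4.5-fold lower number from compound 3 to compound 4 (0.65 log units; beyond the scatter), whereas the two earlier pyrrolidine groups had stayed within the scatter of each other. The change from compound 2 keeps the heavy-atom count, exchanges an oxygen for a nitrogen and adds a hydrogen-bond donor, and the result also brings the pyrrolidine series level with the imidazole compound, with a 1.5-fold lower number from compound 1 to compound 4 (0.18 log units; within the scatter). No measurement shown explains the gain.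

Going by these compounds, the written structures of compound 2 and compound 4 also carry opposite configurations at the pyrrolidine stereocentre, so the share of that difference in the first step stays open. Also open, on these data alone, is whether a methyl urea or an N-methyl-N-tert-butyl urea would hold the number.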